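The source may hold more compounds than are shown below. What is called first, only, known or untested is meant among the compounds shown, and "the series" means these compounds.

Among the compounds with values here, compound 1, `OC[C@H]1O[C@@H](n2cnc3c(NCc4ccc(Cl)cc4)ncnc32)[C@H](O)[C@@H]1O`, is the only compound with a number: in a functional assay on K562 cells (Homo sapiens) for antiproliferative activity, with a stated time of 72 h (a lower number here means a stronger inhibitor, a higher number a weaker inhibitor), compound 1 gives 218000 nM. Compound 2, `OC[C@H]1O[C@@H](n2cnc3c(NCc4c(F)ccc(F)c4F)ncnc32)[C@H](O)[C@@H]1O`, reaches only the limit of the measurement, > 166000 nM in this assay, so no number is known for it. 

Within the data shown here, the step that the limit leaves unreadable from compound 1 to compound 2 therefore cannot be read; this is the only measured step and it rests on (the limit of > 166000 nM in this assay, at which 1 of the 2 values shown sits). The compound still to be measured is compound 3, `OC[C@H]1O[C@@H](n2cnc3c(NCc4cccc(O)c4O)ncnc32)[C@H](O)[C@@H]1O`. It differs from compound 1 by 2,3-dihydroxyphenyl in place of 4-chlorophenyl on a saturated chain carbon bound to a nitrogen on an aromatic ring. Among the measured compounds shown here, no measured step shows what a 2,3-dihydroxyphenyl does, and the one step that exists is unreadable, so nothing beyond the scatter can be expected in either direction. The estimate for compound 3 in this assay is therefore set close to compound 1, at 200000 nM, within 50000 nM to 800000 nM, which is expected to mean a step of a 1.1-fold lower number from compound 1 to compound 3 (0.04 log units; within the scatter).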

Compound 3, half-maximal inhibitory concentration: 25800 nM
Compound 3: the middle estimate sits 7.8-fold (0.89 log units) above what was measured, and the stated range ends above it.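

The group on a saturated chain carbon bound to a nitrogen on an aromatic ring can clearly move the read-out in this assay: 2,3-dihydroxyphenyl in place of 4-chlorophenyl gives an 8.4-fold lower number from compound 1 to compound 3 (0.93 log units; beyond the scatter). Putting the same group in place of 2,3,6-trifluorophenyl gives an at least 6.4-fold lower number from compound 2 to compound 3 (0.80 log units; beyond the scatter), so the dihydroxy group stands apart from both halogen-bearing groups shown. The size of that second step rests on a compound whose value is a limit and not a number, compound 2: the limit of > 166000 nM in this assay, at which 1 of the 3 values shown sits.

Whether both hydroxy groups of compound 3 are needed stays open, as no compound shown carries only one of them or a methoxy group in their place. Also open, going by these compounds, is whether an amine on the same ring would give a similar step, and whether the gain comes from adding the hydroxy groups or from losing the halogens.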